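Cytotoxicity notes on a pyridazinone-amide series

This account rests on a few compounds, and the source may have more. Where it says the series, first, only, none or still open, it means among the compounds named here.

Measured compounds:
- compound 1 `CNC(=O)c1cc(Oc2ccc(NC(=O)c3nn(-c4ccc(Br)cc4F)c(=O)cc3C)cc2F)ccn1` — 7930 nM
- compound 2 `Cc1cc(=O)n(-c2ccccc2OC(F)(F)F)nc1C(=O)Nc1ccc(Oc2ncnc3ccsc23)cc1` — 10100 nM

Two compounds have been run in a functional assay on A549 cells (Homo sapiens) for cytotoxicity, read by MTT assay, with a stated time of 72 h; on this read-out higher numbers stand for weaker inhibition and lower numbers for stronger inhibition. Compound 1 gives 7930 nM. Compound 2 gives 10100 nM, the higher of the two numbers, but the gap to compound 1 is within the scatter, so the two cannot be ordered on these data.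

Compound 3 `Cc1ccc(-n2nc(C(=O)Nc3ccc(Oc4ncnc5ccsc45)cc3)c(C)cc2=O)cc1` is the next member to be measured in this assay. It differs from compound 2 in one place: 4-methylphenyl in place of 2-(trifluoromethoxy)phenyl on an aromatic nitrogen. Going by the values given here, both measured compounds lie close together, and no step between them has been characterised, so there is no basis for expecting a large move in either direction. The estimate for compound 3 in this assay is therefore set near the values of compound 1 and compound 2, at 9000 nM with a range from 3000 nM to 30000 nM. The expected step is a 1.1-fold lower number from compound 2 to compound 3 (0.05 log units; within the scatter), none beyond the scatter.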

Compound 3, half-maximal inhibitory concentration: 11500 nM
For compound 3 the middle estimate is 1.3-fold (0.11 log units) below the measured one, within the range that was stated.
By their numbers in this assay, from the lowest: compounds 1, 2 and 3 (each within the scatter of the next).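

In this assay, going by these compounds alone, 4-methylphenyl in place of 2-(trifluoromethoxy)phenyl on the aromatic nitrogen gives a 1.1-fold higher number from compound 2 to compound 3 (0.06 log units; within the scatter), the first step that can be read at this position, and it lies within the scatter. Across this pair, the change from a group of 11 heavy atoms containing oxygen and fluorine to one of 7 carbon atoms produces no difference that can be told from the scatter. Nothing available bears on why the number holds across this change.

From the compounds shown here alone, whether a phenyl ring carrying an amine or a carboxylic acid at this position would give a step beyond the scatter remains open. Also open, going by these compounds, is whether the same exchange would behave alike on the core of compound 1, which differs from compound 2 in more than one place.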